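The compounds below may be only part of what the source reports. "The series", "measured", "known", "first", "only" and "open" are said of these compounds alone.

Compound 1 `CC(=O)OCC[C@@H]1C[C@@H](c2ccc(F)c(F)c2)[C@H](NC(=O)c2cc(-c3c(Cl)cnn3C)c(Cl)o2)CN1` gives 690 nM in a functional assay on HCT-116 cells (Homo sapiens) for antiproliferative activity, read by sulforhodamine B assay, with a stated time of 72 h; a lower number here means a stronger inhibitor, a higher number a weaker inhibitor. Two dichlorophenyl analogues sit alongside it: compound 2 `COCC[C@@H]1C[C@@H](c2ccc(Cl)c(Cl)c2)[C@H](NC(=O)c2cc(-c3c(Cl)cnn3C)c(Cl)o2)CN1` gives 470 nM and compound 3 `Cn1ncc(Cl)c1-c1cc(C(=O)N[C@@H]2CN[C@H](CCO)C[C@H]2c2ccc(Cl)c(Cl)c2)oc1Cl` gives 340 nM. Compound 1 thus carries the highest of the three numbers, though its gap to compound 2 lies within the scatter; only its gap to compound 3 lies beyond it.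

For the measured compounds named here, the one measured step within the set is a 1.4-fold lower number from compound 2 to compound 3 (0.14 log units; within the scatter), and it does not leave the scatter.

Compound 4 `Cn1ncc(Cl)c1-c1cc(C(=O)N[C@@H]2CN[C@H](CC(O)CO)C[C@H]2c2ccc(F)c(F)c2)oc1Cl` is taken from compound 1 by 1,2-dihydroxyethyl in place of acetoxymethyl on a saturated chain carbon bound to a saturated ring carbon. The change from compound 2 to compound 3 is the closest guide: it likewise uncaps an oxygen on the same chain, and it moved the number only slightly toward lower values. Compound 4 is therefore expected to give a number near that of compound 1, with at most a modest drift toward a lower value; the estimated step is a 1.4-fold lower number from compound 1 to compound 4 (0.16 log units; within the scatter). Compound 4 is estimated at 480 nM, with a range from 200 nM to 1150 nM.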

Compound 4, half-maximal inhibitory concentration: 800 nM
Estimate against measurement, compound 4: 1.7-fold (0.22 log units) below, within the range that was stated.
By their numbers in this assay, from the lowest: compounds 3, 2, 1 and 4 (each within the scatter of the next, the first and the last beyond it).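

In this assay the exchange of acetoxymethyl for 1,2-dihydroxyethyl gives a 1.2-fold higher number from compound 1 to compound 4 (0.06 log units; within the scatter) on a saturated chain carbon bound to a saturated ring carbon. The count at this place thus goes from 0 hydrogen-bond donors to 2 hydrogen-bond donors, and a double bond outside aromatic rings is lost, without a step beyond the scatter. The earlier 1.4-fold lower number from compound 2 to compound 3 (0.14 log units; within the scatter) covered only hydrogen in place of methyl on an oxygen, so the new step extends the reading within the scatter to a larger exchange at the chain end, and no measurement at hand explains either step.

Still open, on these data alone, is whether an amine or a carboxylic acid in place of 1,2-dihydroxyethyl would also stay within the scatter. As far as these compounds go, a longer chain at this place is equally open, as is the step to 1,2-dihydroxyethyl in the dichlorophenyl analogues.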